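Octyl in place of 4-methoxy-2-nitrophenyl: an expected step

The compounds below may be only part of what the source reports. "The series", "measured", "known", "first", "only" and "open" are said of these compounds alone.

In a functional assay on MCF7 cells (Homo sapiens) for antiproliferative activity, read by MTT assay (on this read-out higher numbers stand for weaker inhibition and lower numbers for stronger inhibition), compound 1 (`CC1(C)CCc2cc(C(=O)/C=C/c3ccc(OCc4cn(-c5ccc(Cl)cc5)nn4)cc3)c(O)cc2O1`) gives "not active" (no number reported), which provides no number. Among the measured compounds shown here, compound 2 (`COc1ccc(-n2cc(COc3ccc(/C=C/C(=O)c4ccc5c(c4O)CCC(C)(C)O5)cc3)nn2)c([N+](=O)[O-])c1`) gives 73100 nM, the only number available, so it cannot yet be ranked against a measured neighbour. Compound 3 (`CCCCCCCCn1cc(COc2ccc(/C=C/C(=O)c3ccc4c(c3O)CCC(C)(C)O4)cc2)nn1`) has not yet been measured in this assay. It carries octyl in place of 4-methoxy-2-nitrophenyl on an aromatic nitrogen of a five-membered aromatic ring with 3 nitrogen: octyl in place of 4-methoxy-2-nitrophenyl on an aromatic nitrogen. For the measured compounds named here, no step between measured compounds is available to size this change, so the expectation is loose: a moderate move toward stronger inhibition, with a return to the level of the only number well within reach. The expected change is a 2.4-fold lower number from compound 2 to compound 3 (0.39 log units; beyond the scatter). The estimated value for compound 3 is 30000 nM, within an expected range of 8000 nM to 100000 nM. A result without a number, as with compound 1 at "not active" (no number reported), also remains possible.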

Compound 3, half-maximal inhibitory concentration: "not active" (no number reported)
No number was reported for compound 3; no gap can be computed for the estimate.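

In this assay, among the compounds shown here, compound 3 gives "not active" (no number reported) and so, with no number, yields no step from compound 2. Nothing measured here bears on a cause for this result. The compounds shown leave open how large the change from 4-methoxy-2-nitrophenyl to octyl actually is.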